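The compounds below may be only part of what the source reports. "The series", "measured", "known", "first", "only" and "open" are said of these compounds alone.

Measured compounds in a functional assay on WI-38 VA13 cells (Homo sapiens) for cytotoxicity; a lower number here means that less compound is needed, a higher number that more compound is needed for the effect:
compound 1, `Cc1c(C(=O)c2cccc(CN(C)C)c2)oc2cc(-c3ccccc3)cc(O)c12`, 0.09 ug/mL
compound 2, `COCc1ccccc1C(=O)c1oc2cc(-c3ccccc3)cc(O)c2c1C`, 0.1 ug/mL
compound 3, `COc1ccc(OC)c(C(=O)c2oc3cc(-c4ccccc4)cc(O)c3c2C)c1`, 0.09 ug/mL

All three share one core and differ only in the substitution of the six-membered aromatic ring of carbon only that is attached through the carbonyl. In this assay compound 1 stands level with compound 3 at the digits printed, and compound 2 lies within the scatter of both; the three numbers therefore cannot be separated, and none of the three can be called the most or least active.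

Compound 4, `Cc1c(C(=O)c2cccc(C(F)(F)F)c2)oc2cc(-c3ccccc3)cc(O)c12`, has not yet been measured in this assay. It is derived from compound 1 by a single change: trifluoromethyl in place of (dimethylamino)methyl on an aromatic carbon. Within the data shown here, no measured pair in the set shows what this change does, so nothing on its direction is known from the data. What the set does show is that three rather different substituents on the same ring give numbers within the scatter of one another, which argues for a step from compound 1 to compound 4 that stays within the scatter; a 1.3-fold higher number from compound 1 to compound 4 (0.12 log units; within the scatter) is the expected step, with neither direction favoured. For compound 4 in this assay the estimate is 0.12 ug/mL, with a range from 0.05 ug/mL to 0.3 ug/mL.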

Compound 4, half-maximal effective concentration: > 4 ug/mL
Compound 4 gave a limit, no number (the forecaster's own chance of this, stated with the estimate: 5%); at least 33-fold (1.52 log units) between middle value and limit.
By their numbers in this assay, from the lowest: compounds 1, 3 and 2 (each within the scatter of the next). At a limit, above all of these: compound 4.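

In this assay compound 4 gives > 4 ug/mL, which is a limit of the assay and not a number. Trifluoromethyl in place of (dimethylamino)methyl, on an aromatic carbon meta to a large group, is the only one-place change in the set, and it gives an at least 44-fold higher number from compound 1 to compound 4 (1.64 log units; beyond the scatter); the group at this place therefore matters for this read-out, which the close numbers of compounds 1, 2 and 3 could not show. The full size of the step stays unknown because the read-out ends at a limit: the limit of > 4 ug/mL in this assay, at which 1 of the 4 values shown sits.

A single pair cannot tell whether the higher number goes with the loss of (dimethylamino)methyl or with the arrival of trifluoromethyl, and the data give no cause for either. An aminomethyl group with a primary amine, a longer chain ending in dimethylamino, a nitrile or a carboxylic acid on the same aromatic carbon would show whether the amine itself is what keeps the number low in this series.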